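Working notes: trimethoxyphenyl series, compound 3 pending

A few compounds are considered here, and "the series" means these few. Any claim that something is new, unique, unknown or untested is made for them only; others in the source may bear on it.

Measured so far:
compound 1 `COc1cc(N2C(N)=C(C#N)C(c3ccc([N+](=O)[O-])cc3)C3=C2CC(C)(C)CC3=O)cc(OC)c1OC`: 50%
compound 2 `COc1ccc(C2C(C#N)=C(N)N(c3cc(OC)c(OC)c(OC)c3)C3=C2C(=O)CC(C)(C)C3)cc1`: 1%

In a functional assay on Ehrlich cells (Mus musculus) for cytotoxicity, tested at 25 ug/mL (a lower number here means a weaker effect, a higher number a stronger effect of the compound at the concentration tested), compound 2 stands lowest of the two numbers, below compound 1. Within the data shown here, the single measured step, a number 49 percentage points lower from compound 1 to compound 2 (beyond the scatter), came with methoxy in place of nitro on an aromatic carbon. Compound 3 `COc1cc(N2C(N)=C(C#N)C(/C=C/c3ccccc3)C3=C2CC(C)(C)CC3=O)cc(OC)c1OC` awaits measurement and differs from compound 2 by 2-phenylethenyl in place of 4-methoxyphenyl on a saturated ring carbon. The measured step bears on this only in that the methoxy leaves again, so a moderate rise is expected, well short of the measured step. Compound 3 is estimated at 20%, range 3% to 50%, an expected step of a number 19 percentage points higher from compound 2 to compound 3 (beyond the scatter).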

Compound 3, a percentage reported as activity, at one concentration (the size of the read-out at that concentration, not a potency): 30%
Beside the measured number, compound 3's estimate is 10 percentage points below it, and the stated range covers the measured number.
By their numbers in this assay, from the lowest: compound 2; then compound 3; then compound 1.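

At the saturated ring carbon, an aromatic ring bonded directly to that carbon is not needed for a clear effect in this assay: 2-phenylethenyl in place of 4-methoxyphenyl gives a number 29 percentage points higher from compound 2 to compound 3 (beyond the scatter) at this position. The same group in place of 4-nitrophenyl gives a number 20 percentage points lower from compound 1 to compound 3 (beyond the scatter), so it recovers part of the read-out but does not match 4-nitrophenyl. No available evidence accounts for these steps.

Open, as far as these compounds go, is how a saturated 2-phenylethyl group or a 4-aminophenyl group at this carbon would compare. Also open, from the compounds shown here alone, is whether this order holds at other concentrations.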